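The compounds below may be only part of what the source reports. "The series", "measured", "known", "first", "only" and "open" are said of these compounds alone.

Compound 1 `O=C(NCc1ccccn1)c1ncc([N+](=O)[O-])[nH]1`: > 100000 nM (a limit)
Compound 2 `O=C(NC1CC1)c1ncc([N+](=O)[O-])[nH]1`: > 100000 nM (a limit)
Compound 3 `NC(=O)c1ncc([N+](=O)[O-])[nH]1`: > 100000 nM (a limit)

These three entries come from a toxicity assay on HEK293 cells (Homo sapiens) for inhibition, read by resazurin assay, with a stated time of 24 h (on this read-out lower numbers stand for higher toxicity in this test and higher numbers for lower toxicity in this test), and none of them is an exact number. Compound 3, the starting point here, has only a limit, > 100000 nM. It shares that limit with the other two compounds: the limit of > 100000 nM in this assay, at which 3 of the 3 values shown sit.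

The next compound, compound 4 `O=C(NCCO)c1ncc([N+](=O)[O-])[nH]1`, is not yet measured. It differs from compound 3 by 2-hydroxyethyl in place of hydrogen on an amide-type nitrogen. In words, 2-hydroxyethyl stands in place of hydrogen on an amide-type nitrogen.

Going by the values given here, the one measured step at this same nitrogen is a step that the two limits leave unreadable from compound 2 to compound 3. It swaps cyclopropyl for hydrogen, and its size cannot be read, so it offers no measured size to carry over. What it does show is that a group on this nitrogen leaves the result at a limit, since compound 2 gives > 100000 nM. Compound 1, which also carries a group there, gives > 100000 nM, again a limit.

No step beyond the usual scatter is therefore expected in this assay, in either direction. The expected change is a step that the limit leaves unreadable from compound 3 to compound 4. Compound 4 is most likely to be reported as a limit too. As a value, compound 4 is estimated at 120000 nM, with an expected range from 60000 nM to 250000 nM.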

Compound 4, half-maximal cytotoxic concentration: > 100000 nM
Compound 4 was reported as a limit; the forecaster's own chance of this, stated with the estimate: 85%; the middle value does not contradict the limit.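

Compound 4 also gives a limit in this assay, > 100000 nM. The steps to compound 4 from compound 1, compound 2 and compound 3 therefore cannot be read, as all four compounds share one limit: the limit of > 100000 nM in this assay, at which 4 of the 4 values shown sit.

From the compounds shown here alone, what stays open is how far each compound lies beyond that limit, and whether any group on this amide-type nitrogen would give an exact number.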